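The source may hold more compounds than are shown below. What is called first, only, known or untested is meant among the compounds shown, and "the series" means these compounds.

Series notes. In a physicochemical assay for solubility, in phosphate buffer, at pH 7.4 (on this read-out lower numbers stand for lower solubility and higher numbers for higher solubility), compound 1 `CCOC(=O)c1c(-c2cccc(Cl)c2)[nH]c2cc(OC)ccc2c1=O` gives 58000 nM, compound 2 `CCOC(=O)c1c(-c2ccc(C(C)(C)C)cc2)[nH]c2cc(OC)ccc2c1=O` gives 2000 nM, and compound 3 `CCOC(=O)c1c(-c2ccc(Cl)c(Cl)c2)[nH]c2cccc(OC)c2c1=O` gives 39000 nM. On these three numbers compound 3 stands second highest; its nearest neighbour is compound 1, whose value sits within the scatter of that of compound 3, while compound 2 lies well below both, beyond the scatter.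

Compound 4 `CCOC(=O)c1c(-c2cccc(C)c2)[nH]c2cccc(OC)c2c1=O` is not yet measured in this assay. It differs from compound 3 in one place: 3-methylphenyl in place of 3,4-dichlorophenyl on an aromatic carbon. Both groups that leave and enter carry no hydrogen-bond donors or acceptors and no net charge. Among the measured compounds shown here, no measured pair in the set differs in exactly this way, so the size of the step can only be read against the spread of the three values. Compound 1 gives 58000 nM and compound 3 gives 39000 nM, two values within the scatter of each other, and nothing in the set points to a move toward the low value of compound 2.

A step from compound 3 to compound 4 of a 1.5-fold higher number from compound 3 to compound 4 (0.19 log units; within the scatter) is expected, upward but within the scatter. Compound 4 is therefore estimated at 60000 nM in this assay, with a range from 20000 nM to 180000 nM.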

Compound 4, solubility: > 100000 nM
Compound 4 gave a limit, no number; the forecaster's own chance of this, stated with the estimate: 5%; middle value at least 1.6-fold (0.22 log units) away from the limit.
By their numbers in this assay, from the lowest: compound 2; then compounds 3 and 1 (each within the scatter of the next). At a limit, above all of these: compound 4.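

In this assay, 3-methylphenyl in place of 3,4-dichlorophenyl, on the aromatic carbon next to the ring nitrogen and ortho to an ethoxycarbonyl group, gives an at least 2.5-fold higher number from compound 3 to compound 4 (0.40 log units; beyond the scatter). Among the compounds shown here, this is the first comparison that differs in one place, so it is the first direct evidence that the aryl group at this position can move this read-out beyond the scatter. Compound 4 gives a limit and not a number, so the step has a lower bound only and its full size is unknown: the limit of > 100000 nM in this assay, at which 1 of the 4 values shown sits.

The single step changes the ring's chlorine substituents and adds the methyl together, so the compounds shown do not separate these contributions. Going by these compounds, how a carboxylic acid or an amine on this aryl ring would read in this assay also stays open.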